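The source may hold more compounds than are shown below. What is called first, only, known or untested is meant among the compounds shown, and "the series" means these compounds.

Measured so far:
compound 1 `COc1cc(Cl)cc(-c2nn(-c3cccc(NC(=O)Nc4ccc(Cl)c(C(F)(F)F)c4)c3)cc2-c2ccncc2)c1` gives 79%
compound 2 `COc1cc(Cl)cc(-c2nn(-c3cccc(NC(=O)Nc4ccc(Cl)c(Cl)c4)c3)cc2-c2ccncc2)c1` gives 50%

Both were tested in a functional assay on Malme-3M cells (Homo sapiens) for inhibition, read by sulforhodamine B assay, with a stated time of 48 h, tested at 0.1 uM; on this read-out higher numbers stand for a weaker effect at the one concentration tested and lower numbers for a stronger effect. Going by the values given here, compound 2 stands lowest of the two numbers, so its effect on the cells is the stronger one; its nearest neighbour is compound 1, and the one measured step, a number 29 percentage points lower from compound 1 to compound 2 (beyond the scatter), lies beyond the scatter.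

Compound 3 `COc1cc(Cl)cc(-c2nn(-c3cccc(NC(=O)Nc4cccc(C(F)(F)F)c4)c3)cc2-c2ccncc2)c1` has not been measured. It differs from compound 2 in one place: 3-(trifluoromethyl)phenyl in place of 3,4-dichlorophenyl on an amide-type nitrogen. This change runs the measured step partly backwards, since a trifluoromethyl group returns where compound 1 also carried one, while compound 1 in addition kept a chloro group that compound 3 lacks. Among the compounds with values here, no measured pair shows what removing that chloro group alone does.

Because a number 29 percentage points lower from compound 1 to compound 2 (beyond the scatter) was a modest fall when chloro replaced trifluoromethyl, a rise of similar size is expected on the way back, so compound 3 is expected to give 72%, within 48% to 95%, a step of a number 22 percentage points higher from compound 2 to compound 3 (beyond the scatter) that is expected to be beyond the scatter but uncertain in size.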

Compound 3, a percentage reported as activity, at one concentration (the size of the read-out at that concentration, not a potency): 50%
Beside the measured number, compound 3's estimate is 22 percentage points above it; low and high end bracket the measured number.
By their numbers in this assay, from the lowest: compounds 2 and 3 (each within the scatter of the next); then compound 1.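

Replacing 3,4-dichlorophenyl with 3-(trifluoromethyl)phenyl on the amide-type nitrogen gives no change at the digits printed from compound 2 to compound 3 (within the scatter) in this assay, so these two aryl groups cannot be told apart on this read-out, and a trifluoromethyl group alone does not restore the weaker effect seen with compound 1. Putting hydrogen in place of chloro on an aromatic carbon gives a number 29 percentage points lower from compound 1 to compound 3 (beyond the scatter), which shows that the weaker effect depends on trifluoromethyl and chloro being present together in this set, since either compound that lacks one of them gives the stronger effect. No supporting evidence is available to explain why this combination stands apart.

The compounds shown leave open what a phenyl ring carrying only one chloro group, or no group at all, would give, and so how much the aryl group matters at this place. On these data alone, a methoxy group or an amine on this ring also remains open, as does whether this pattern would hold at concentrations other than the single one used here.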